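From a Limit Value: Adding 4-Hydroxybenzyl to Compound 1

This account rests on a few compounds, and the source may have more. Where it says the series, first, only, none or still open, it means among the compounds named here.

Compound 1 `COc1ccc2[nH]c(-c3cc(OC)c(OC)c(OC)c3)cc2c1` was tested in a functional assay on MDA-MB-231 cells (Homo sapiens) for cytotoxicity, read by MTT assay, with a stated time of 24 h (a lower number here means a stronger inhibitor, a higher number a weaker inhibitor), and compound 1 gives > 30000 nM, which is a limit and not a number. Compound 2 `COc1ccc2c(c1)c(Cc1ccc(OCc3ccccc3)cc1)c(-c1cc(OC)c(OC)c(OC)c1)n2Cc1ccc(OCc2ccccc2)cc1` gives > 30000 nM in this assay, again a limit. Going by the values given here, the record so far therefore consists of the limit of > 30000 nM in this assay, at which 2 of the 2 values shown sit, and no measured step connects the two compounds.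

Compound 3 `COc1ccc2c(c1)cc(-c1cc(OC)c(OC)c(OC)c1)n2Cc1ccc(O)cc1` has not yet been measured. It is compound 1 with 4-hydroxybenzyl in place of hydrogen on an aromatic nitrogen, next to the ring atom that bears a large group: 4-hydroxybenzyl in place of hydrogen on an aromatic nitrogen. With compound 1 at the limit > 30000 nM, the size of any change cannot be read from the data, so only a modest gain in strength is expected, and the result may well stay at a limit. The expected step in this assay is an at least 2.0-fold lower number from compound 1 to compound 3 (0.30 log units; that floor lies within the scatter), towards a stronger inhibitor. For compound 3 the estimated half-maximal inhibitory concentration is 15000 nM, with an expected range from 3000 nM to 30000 nM.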

Compound 3, half-maximal inhibitory concentration: 17300 nM
Estimate against measurement, compound 3: 1.2-fold (0.06 log units) below; the measured number falls inside the stated range.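

Putting 4-hydroxybenzyl in place of hydrogen on an aromatic nitrogen gives a measured number in this assay and not a limit, which neither earlier compound offered: compound 3 gives 17300 nM. The change amounts to an at least 1.7-fold lower number from compound 1 to compound 3 (0.23 log units; that floor lies within the scatter), and this is only a floor, so its true size cannot be read, and the floor alone does not establish a real gain in strength. What the result does show is that a substituent on this nitrogen of the core of compound 1 can go with a number inside the measurable range, and compound 3 is the only compound shown that does not sit at the limit: the limit of > 30000 nM in this assay, at which 2 of the 3 values shown sit.

The compounds shown leave open whether the number depends on the hydroxyl of the 4-hydroxybenzyl group or on the benzyl part alone, a question that a plain benzyl, a 4-methoxybenzyl or a 4-aminobenzyl on the same nitrogen would address. They also leave open whether a longer chain between this nitrogen and the phenol ring, such as 2-(4-hydroxyphenyl)ethyl, would move the number in either direction.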